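Methoxy removal in a pyrrolidine series: alpha-mannosidase inhibition

The source may hold more compounds than are shown below. What is called first, only, known or untested is meant among the compounds shown, and "the series" means these compounds.

Two members of the series have been measured. Compound 1, `COc1ccc([C@]2(CO)NC[C@@H](O)[C@@H]2O)cc1`, carries the methoxy group at one position of its phenyl ring, and compound 2, `COc1cccc([C@]2(CO)NC[C@@H](O)[C@@H]2O)c1`, carries it at another. In an assay on isolated protein for inhibition of alpha-mannosidase (Canavalia ensiformis), tested at 1000 uM (on this read-out lower numbers stand for less inhibition and higher numbers for more inhibition at the one concentration tested (going by the name of the read-out)), compound 1 gives 0.2%, and in this assay compound 2 gives 0%. Compound 2 thus sits at the bottom of the two numbers, but the gap to compound 1 lies within the scatter, so the two readings are treated as equivalent; both sit at the floor of the read-out.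

Compound 3, `OC[C@@]1(c2ccccc2)NC[C@@H](O)[C@@H]1O`, has not yet been measured in this assay. It differs from compound 2 in one place: hydrogen in place of methoxy on an aromatic carbon. Among the compounds with values here, no pair of measured compounds differing in a single position is available, so nothing here tells how large a step this change produces. Given that compound 2 shows essentially no inhibition at 0% and compound 1 likewise at 0.2%, a step no larger than the scatter is expected in either direction. For compound 3 the value expected in this assay is 1%, with a range from -6% to 12%. The expected step from compound 2 is a number 1 percentage points higher from compound 2 to compound 3 (within the scatter), which is taken as no change beyond the scatter.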

Compound 3, a percentage reported as inhibition, at one concentration (the size of the read-out at that concentration, not a potency): 0%
Beside the measured number, compound 3's estimate is 1 percentage points above it; low and high end bracket the measured number.
By their numbers in this assay, from the lowest: compounds 2, 3 and 1 (each within the scatter of the next).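

Hydrogen in place of methoxy on an aromatic carbon now gives the first single-place steps in the series: in this assay the change reads no change at the digits printed from compound 2 to compound 3 (within the scatter), and with the methoxy at the other ring position it reads a number 0.2 percentage points lower from compound 1 to compound 3 (within the scatter). Within the data shown here, at this read-out, therefore, methoxy at either ring position cannot be told apart from hydrogen, and the compound without methoxy stays at the floor with the other two; since all three readings lie there, the steps show only that this change brings no inhibition into view, not that the group is without any influence. No measurement at hand bears on why the readings stay at the floor.

Going by these compounds, whether another group on this aromatic carbon, such as an amine, a carboxylic acid or a longer alkoxy chain, would bring a reading clear of the floor remains open. Also open, on these data alone, is whether a change elsewhere on the shared core, for instance replacing the hydroxymethyl group with an aminomethyl group, would give the series a reading against which ring substitution could be compared.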